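Replacing 2,5-Difluorophenyl with 3-Methylphenyl: What to Expect

A few compounds are considered here, and "the series" means these few. Any claim that something is new, unique, unknown or untested is made for them only; others in the source may bear on it.

Three compounds have been measured in an assay on CHO cells for displacement of a labelled ligand from adenosine receptor A1 (Homo sapiens), read by scintillation counting, tested at 10 uM; a lower number here means less inhibition, a higher number more inhibition at the concentration tested (going by the name of the read-out):

Compound 1, `Nc1sc(-c2ccccc2)c(-c2ccccc2)c1C(=O)c1ccc(Cl)cc1`, gives 1%.
Compound 2, `CC(C)(C)Cc1c(-c2cccnc2)sc(N)c1C(=O)c1ccc(Cl)cc1`, gives 1%.
Compound 3, `CC(C)(C)Cc1c(-c2cc(F)ccc2F)sc(N)c1C(=O)c1ccc(Cl)cc1`, gives 3%.

All three numbers lie close together, and the gaps between them fall within the usual scatter of this kind of measurement, so none of the three can be called stronger or weaker than the others; each shows only slight inhibition at the concentration tested. Compound 3 is the starting point for the next step, and its number stands within the scatter of both compound 1 and compound 2.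

Compound 4, `Cc1cccc(-c2sc(N)c(C(=O)c3ccc(Cl)cc3)c2CC(C)(C)C)c1`, differs from compound 3 in one place: 3-methylphenyl in place of 2,5-difluorophenyl on an aromatic carbon.

For the measured compounds named here, one measured step bears on this change, since it alters the same aromatic carbon: a number 2 percentage points higher from compound 2 to compound 3 (within the scatter). That swap of one six-membered aromatic ring for another left the number essentially unchanged. Compound 1 also carries a plain six-membered aromatic ring of carbon at this place and shows a similarly low number. Given this, the step of a number 1 percentage points lower from compound 3 to compound 4 (within the scatter) is expected to stay within the scatter, with no direction beyond it. Compound 4 is therefore estimated at 2%, with a range from 0% to 10%.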

Compound 4, a percentage reported as inhibition, at one concentration (the size of the read-out at that concentration, not a potency): 1%
For compound 4 the middle estimate is 1 percentage points above the measured one; low and high end bracket the measured number.
By their numbers in this assay, from the lowest: compounds 1, 2, 4 and 3 (each within the scatter of the next).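

In this assay, 3-methylphenyl in place of 2,5-difluorophenyl gives a number 2 percentage points lower from compound 3 to compound 4 (within the scatter) and 3-methylphenyl in place of pyridin-3-yl gives no change at the digits printed from compound 2 to compound 4 (within the scatter). This aromatic carbon, next to the ring sulfur, has now carried three different six-membered aromatic rings on the same neopentyl-bearing core: one with a ring nitrogen, one with two fluorines and one with a methyl group, and compounds 2, 3 and 4 all remain within the scatter of one another, with no exception among them. No independent measurement is available to explain why these three rings give such similar numbers.

From the compounds shown here alone, it remains open whether a group of a different kind on this carbon, such as a carboxylic acid, an amine or a longer alkyl chain, would move the number beyond the scatter. Going by these compounds, it is also open whether the same ring swaps would leave the number unchanged in a related compound that gives a clearly higher reading at this concentration.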